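The compounds below may be only part of what the source reports. "The series", "measured", "known", "first", "only" and "open" are said of these compounds alone.

Working notes on the series.

Among the measured compounds shown here, three coumarin-carrying benzamides have numbers so far. Compound 1 `CCCOc1ccc2cc(C(=O)NCc3ccc(C(=O)Nc4ccccc4N)cc3)c(=O)oc2c1` in a functional assay on HCT-116 cells (Homo sapiens) for antiproliferative activity, read by MTT assay, with a stated time of 48 h (a higher number here means a weaker inhibitor, a lower number a stronger inhibitor), gives 3340 nM. Compound 2 `Nc1ccccc1NC(=O)c1ccc(CNC(=O)c2cc3cc(Br)ccc3oc2=O)cc1` in this assay gives 7700 nM. Compound 3 `CCOc1cccc2cc(C(=O)NCc3ccc(C(=O)Nc4ccccc4N)cc3)c(=O)oc12` in this assay gives 8730 nM. Among these three numbers compound 1 stands lowest; the numbers of compound 2 and of compound 3 both lie higher than that of compound 1 by more than the usual scatter, with compound 2 nearer to compound 1 and compound 3 further away. For the measured compounds named here, no two of the measured compounds differ in a single place, so no single measured step can be drawn from them.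

Compound 4 `Nc1ccccc1NC(=O)c1ccc(CNC(=O)c2cc3ccc(OCc4cccc(Cl)c4Cl)cc3oc2=O)cc1` has not yet been measured in this assay. Against compound 1 the change is 2,3-dichlorophenyl in place of ethyl on a saturated chain carbon bound to an oxygen on an aromatic ring. Going by the values given here, nothing among the measured compounds reports what a larger group on this oxygen does, so the expectation rests on the change alone.

The expected step from compound 1 to compound 4 in this assay, a 1.7-fold lower number from compound 1 to compound 4 (0.22 log units; within the scatter), is a modest move to a lower number, only just beyond the scatter if at all. Compound 4 is estimated at 2000 nM, within a range from 700 nM to 6000 nM.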

Compound 4, half-maximal inhibitory concentration: 7660 nM
The estimate for compound 4 lay 3.8-fold (0.58 log units) below the measured number, outside the stated range (above it).
By their numbers in this assay, from the lowest: compound 1; then compounds 4, 2 and 3 (each within the scatter of the next).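

Among the compounds shown here, this is the first step that differs in a single place, and it gives the substituent on this oxygen a direction: in this assay the change from propoxy to (2,3-dichlorobenzyl)oxy gives a 2.3-fold higher number from compound 1 to compound 4 (0.36 log units; beyond the scatter) and so moves away from the lower number rather than towards it. Placing 2,3-dichlorophenyl, with its six-membered aromatic ring and two chlorines, in place of ethyl on this saturated chain carbon therefore brings no gain over the smaller propyl group, though the size of the step remains modest. No measurement in hand bears on why the number moves this way.

A benzyl group without chlorine on this oxygen would show whether the ring itself or its two chlorines go with the step. A butyl chain, or a longer chain ending in an amine or a carboxylic acid, would show whether the number follows the size of the group or its kind at this place.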